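Cyano in Place of Methyl: Expected Maximal Response

The compounds below may be only part of what the source reports. "The series", "measured", "known", "first", "only" and "open" are said of these compounds alone.

Of the compounds shown here, three have so far been tested in a functional assay on CHO cells for agonist activity at Free fatty acid receptor 1 (Homo sapiens), read by reporter gene assay; a higher number here means a larger maximal response, a lower number a smaller maximal response. Compound 1 `O=C(O)CCCc1ccc(NCc2cccc(Oc3ccccc3)c2)cc1` reaches 74% in this assay. Compound 2 `O=C(O)CCc1ccc(NCc2ccc3ccccc3c2)cc1` reaches 123%. Compound 3 `Cc1ccc(CNc2ccc(CCC(=O)O)cc2)cc1` reaches 152%, the highest of the three numbers; its gap to compound 2 is beyond the usual scatter, and its gap to compound 1 is wider still and also beyond the scatter.

Compound 4 `N#Cc1ccc(CNc2ccc(CCC(=O)O)cc2)cc1` has not yet been measured. It differs from compound 3 in one place only: cyano in place of methyl on an aromatic carbon. Among the measured compounds shown here, no two of the measured compounds differ from each other in just one place, so there is no measured step that shows what such a swap does here. Compounds 1, 2 and 3 differ from one another in several places at once, and their numbers cannot be traced to any single change.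

With nothing to anchor the swap, the plainest expectation is that compound 4 stays close to compound 3, and the step from a number 17 percentage points lower from compound 3 to compound 4 (beyond the scatter) is expected to be small and possibly within the scatter, with a slight lean toward a lower number. In this assay compound 4 is therefore estimated at 135%, within a range from 95% to 170%.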

Compound 4, largest response reached (reported as percent of maximum), in percent of the reference or control that the assay uses: 49%
Beside the measured number, compound 4's estimate is 86 percentage points above it; measured number below the stated range.
By their numbers in this assay, from the lowest: compound 4; then compound 1; then compound 2; then compound 3.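

Cyano in place of methyl on an aromatic carbon gives, in this assay, a number 103 percentage points lower from compound 3 to compound 4 (beyond the scatter), and this is the only step among the compounds shown that can be traced to a single change. It shows that the maximal response is highly sensitive to the group at this place, on the six-membered aromatic ring and para to a large group: the swap adds only one heavy atom and one hydrogen-bond acceptor, yet the number falls far beyond the scatter. Nothing measured on these compounds says what lies behind this fall.

On these data alone, with only methyl and cyano compared at this place, it remains open whether other groups here, such as a chlorine atom, a methoxy group or an amine, would stay near compound 3 or fall toward compound 4. It is also open whether the same swap would have a similar effect on the other compounds shown, since the step has been read on this one pair alone and may not carry over to a different core or a longer chain.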